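A few compounds are considered here, and "the series" means these few. Any claim that something is new, unique, unknown or untested is made for them only; others in the source may bear on it.

Compound 1 `COc1ccc(NC(=O)c2csc(-c3cn(Cc4ccc(Cl)cc4)c4ccccc34)n2)cc1` in a functional assay on LNCaP C4-2 cells (Homo sapiens) for cytotoxicity, read by MTT assay, with a stated time of 48 h, in the absence of a further agent (on this read-out lower numbers stand for stronger inhibition and higher numbers for weaker inhibition), gives > 100000 nM, which is a limit of the assay. Compound 2 `O=C(Nc1ccccc1)c1csc(-c2cn(Cc3ccc(Cl)cc3)c3ccccc23)n1` in this assay gives > 100000 nM, again a limit.

Among the compounds with values here, compound 2 therefore stands only at a limit, and so does the one further value shown, both sitting at the limit of > 100000 nM in this assay, at which 2 of the 2 values shown sit. Within the data shown here, the single measured step, a step that the two limits leave unreadable from compound 1 to compound 2, cannot be read. Compound 3 `COc1cc(NC(=O)c2csc(-c3cn(Cc4ccc(Cl)cc4)c4ccccc34)n2)cc(OC)c1OC` differs from compound 2 by 3,4,5-trimethoxyphenyl in place of phenyl on an amide-type nitrogen. Among the measured compounds shown here, no measured step bears on this change, so no size or direction can be drawn from the data. Compound 3 is estimated at 60000 nM, between 10000 nM and 300000 nM, an expected step of an at least 1.6-fold lower number from compound 2 to compound 3 (0.22 log units; that floor lies within the scatter).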

Compound 3, half-maximal inhibitory concentration: > 100000 nM
Compound 3: a limit, no number (the forecaster's own chance of this, stated with the estimate: 60%); middle value at least 1.6-fold (0.22 log units) from the limit.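

Within the data shown here, compound 3 also stands at a limit of the assay, so no step among compound 1, compound 2 and compound 3 can be read: the limit of > 100000 nM in this assay, at which 3 of the 3 values shown sit. The compounds shown leave open whether any group on the amide-type nitrogen changes the read-out in this assay.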